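Leucine-based diketopiperazines: from aminobutyl to carbamoylethyl

The compounds below may be only part of what the source reports. "The series", "measured", "known", "first", "only" and "open" are said of these compounds alone.

Measured compounds:
compound 1, `CC(C)C[C@@H]1NC(=O)[C@H](CS)NC1=O`, 88.9%
compound 2, `CC(C)C[C@@H]1NC(=O)[C@H](CCCCN)NC1=O`, 96%

Compound 1 and compound 2 share one core and differ only in the side chain on the saturated ring carbon. In a functional assay, tested at 2.5 mM (on this read-out lower numbers stand for less inhibition and higher numbers for more inhibition at the one concentration tested (going by the name of the read-out)), compound 1 gives 88.9%, and in this assay compound 2 gives 96%. Compound 2 thus holds the higher of the two numbers, but the step of a number 7.1 percentage points higher from compound 1 to compound 2 (within the scatter) is within the scatter, so the two compounds cannot be told apart on these numbers.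

Compound 3, `CC(C)C[C@@H]1NC(=O)[C@H](CCC(N)=O)NC1=O`, has not yet been measured in this assay. It differs from compound 2 in one place: carbamoyl in place of 2-aminoethyl on a saturated chain carbon, two bonds along the chain from a saturated ring carbon. Going by the values given here, the only measured step touches the same side chain, and that step, a number 7.1 percentage points higher from compound 1 to compound 2 (within the scatter), stayed within the scatter even though the whole end of the chain was exchanged. On that basis no step beyond the scatter is expected from compound 2 to compound 3, and compound 3 is expected to give 90%, between 75% and 99%, which means an expected step of a number 6 percentage points lower from compound 2 to compound 3 (within the scatter).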

Compound 3, a percentage reported as inhibition, at one concentration (the size of the read-out at that concentration, not a potency): 19%
Compound 3: the middle estimate sits 71 percentage points above what was measured, and the stated range ends above it.
By their numbers in this assay, from the lowest: compound 3; then compounds 1 and 2 (each within the scatter of the next).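

In this assay the step of a number 77 percentage points lower from compound 2 to compound 3 (beyond the scatter) shows that this position is not indifferent to what stands at the end of the side chain, which the earlier pair, lying within the scatter of each other, could not reveal. The step of a number 69.9 percentage points lower from compound 1 to compound 3 (beyond the scatter) is also large, so compound 3 stands apart from both earlier compounds, and this change matters even though 2-aminoethyl and carbamoyl match in heavy atoms, hydrogen-bond donors and hydrogen-bond acceptors, and neither carries a net charge. Nothing available explains why exchanging these two groups has so large an effect on the read-out.

The compounds shown leave open whether the low number belongs to the carbamoyl group itself or would also follow from other chain ends, such as a carboxylic acid in its place. They also leave open how far chain length matters, since a longer chain ending in carbamoyl or a shorter chain ending in an amine could separate the effect of the end group from that of the chain.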